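A few compounds are considered here, and "the series" means these few. Any claim that something is new, unique, unknown or untested is made for them only; others in the source may bear on it.

Of the compounds shown here, three have so far been tested in an assay on isolated protein for inhibition of RAC-alpha serine/threonine-protein kinase (Homo sapiens), read by mobility shift assay, tested at 30 uM; a higher number here means more inhibition at the concentration tested (going by the name of the read-out), a lower number less inhibition. Compound 1 `CC(C)(C)c1cc2[nH]nc(N)c2c(=O)[nH]1` gives 3% in this assay. Compound 2 `COCCNc1nc(C)cc2c1c(N)nn2C` gives 6%. Compound 3 `Cc1cc2nc(N)nc(N)c2c(=O)[nH]1` gives 5%. Compound 3 sits among three numbers that all lie within the usual scatter of one another: its nearest neighbour is compound 2 and its furthest is compound 1, and neither gap is wide enough to count as a real difference. All three numbers are small, so none of these compounds blocks the enzyme to any notable degree at the concentration used.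

Compound 4 `Cc1cc2nc(-c3ccccc3)nc(N)c2c(=O)[nH]1` has not yet been measured. It differs from compound 3 in one place: phenyl in place of amino on an aromatic carbon. For the measured compounds named here, no pair of measured compounds differs in only one place, so there is no measured step to lean on. Compound 3 gives 5%, and the other two compounds fall in the same low band, which gives no sign that this change would move the number much. The expected step is a number 1 percentage points higher from compound 3 to compound 4 (within the scatter), small and not beyond the scatter. Compound 4 is therefore estimated to give 6%, within a range from -5% to 20%.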

Compound 4, a percentage reported as inhibition, at one concentration (the size of the read-out at that concentration, not a potency): 7%
The estimate for compound 4 lay 1 percentage points below the measured number; the range from low to high includes it.
By their numbers in this assay, from the lowest: compounds 1, 3, 2 and 4 (each within the scatter of the next).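

Phenyl in place of amino on an aromatic carbon between two ring nitrogen atoms gives a number 2 percentage points higher from compound 3 to compound 4 (within the scatter) in this assay and this is the first measured step between two compounds that differ in one place. It shows that this position can carry a whole aromatic ring instead of a single amino group without the number leaving the low band, so neither group gives real inhibition at the concentration tested. With both numbers this low, the step cannot show whether either group helps or hinders, and no measurement here offers an explanation.

Still open, from the compounds shown here alone, is whether another group at this position, such as a carboxylic acid, a piperazine or a longer chain, would lift the number clear of the scatter. Going by these compounds, a phenyl ring carrying a hydroxyl group is equally open.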